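From 3-Methylbenzyl to 4-Chlorobenzyl: an Untested Variant

The compounds below may be only part of what the source reports. "The series", "measured", "known", "first", "only" and "open" are said of these compounds alone.

Compound 1 `CSCC[C@H](NC(=O)c1ccc(NCc2cncn2Cc2cccc(C)c2)cc1-c1ccccc1)C(=O)O`: > 10 uM
Compound 2 `N#Cc1ccc(Cn2cncc2CNc2ccc(C(=O)NCc3ccccc3)c(-c3ccccc3)c2)cc1`: > 10 uM

Both measured values here are limits of the assay rather than numbers. In a functional assay on NIH3T3 cells (Mus musculus) (on this read-out higher numbers stand for an effect only at larger amounts of compound and lower numbers for an effect already at smaller amounts), compound 1 gives > 10 uM, which is a limit. In this assay compound 2 gives > 10 uM, also a limit. Compound 1 thus stands at the limit of > 10 uM in this assay, at which 2 of the 2 values shown sit. Among the compounds with values here, with only two limits in hand, no step between measured compounds can be drawn, and no direction of change has been seen.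

Compound 3 `CSCC[C@H](NC(=O)c1ccc(NCc2cncn2Cc2ccc(Cl)cc2)cc1-c1ccccc1)C(=O)O` differs from compound 1 in one place: 4-chlorophenyl in place of 3-methylphenyl on a saturated chain carbon bound to an aromatic nitrogen. Without a measured step to lean on, and with compound 1 already at a limit, the expected step is a step that the limit leaves unreadable from compound 1 to compound 3, none beyond the scatter. Compound 3 is expected to give about 15 uM in this assay, within a range from 4 uM to 60 uM, and most likely to be reported again only as a limit.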

Compound 3, concentration for half-maximal effect: > 10 uM
Compound 3: no number, only a limit; the forecaster's own chance of this, stated with the estimate: 75%; the middle value does not contradict the limit.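

In this assay compound 3 gives > 10 uM, a limit and not a number. Within the data shown here, compound 1 also sits at a limit, and no step from one to the other can be read. The compounds shown leave open whether 3-methylbenzyl and 4-chlorobenzyl differ at all in this assay.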